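The source may report more compounds than this note shows. Statements on the series, on what has been measured and on what is new or still open speak of the compounds shown alone.

Compound 2 `C[C@H](NC(=O)c1cnnn1Cc1ccc(C(F)(F)F)cc1)c1ccc(C(=O)O)cc1` was tested in a functional assay on CHO cells for antagonist activity at prostaglandin E2 receptor EP4 subtype (Homo sapiens), read by calcium flux, with a stated time of 15 min; a higher number here means a weaker inhibitor, a lower number a stronger inhibitor; compound 2 gives only a limit, > 10000 nM, not a number. Compound 1 `C[C@H](NC(=O)c1nnn(Cc2ccc(F)cc2)c1C(F)(F)F)c1ccc(C(=O)O)cc1` likewise gives only a limit in this assay, > 10000 nM. Both measured values therefore sit at the same place, namely (the limit of > 10000 nM in this assay, at which 2 of the 2 values shown sit), so compound 2 stands level with compound 1 as far as the numbers reach. Compound 3 `C[C@H](NC(=O)c1c(C2=CCOCC2)nnn1Cc1ccc(C(F)(F)F)cc1)c1ccc(C(=O)O)cc1` has not yet been measured; it differs from compound 2 by a group of 6 heavy atoms (5 carbon, 1 oxygen; one six-membered non-aromatic ring with 1 hetero atom) in place of a hydrogen atom, on an aromatic carbon. Among the measured compounds shown here, with no measured step to lean on, the step of an at least 5.0-fold lower number from compound 2 to compound 3 (0.69 log units; beyond the scatter) is expected to be a gain in potency beyond the scatter. Compound 3 is therefore estimated at 2000 nM, between 300 nM and 10000 nM.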

Compound 3, half-maximal inhibitory concentration: 119 nM
For compound 3 the middle estimate is 17-fold (1.23 log units) above the measured one, and the stated range ends above it.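

In this assay, replacing the hydrogen atom on this aromatic carbon with the six-membered non-aromatic ring gives an at least 84-fold lower number from compound 2 to compound 3 (1.92 log units; beyond the scatter) and yields a measured number rather than a limit. A change at this one carbon can therefore move potency by a large amount. From the compounds shown here alone, the full size of the step stays unknown, as compound 2 gives only a limit: the limit of > 10000 nM in this assay, at which 2 of the 3 values shown sit.

Going by these compounds, whether the ring oxygen or the ring double bond is needed remains open. So does whether a smaller methyl group or a phenyl ring on this carbon would serve as well.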